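A Smaller Ring on the Amide: Estimating Compound 4

A few compounds are considered here, and "the series" means these few. Any claim that something is new, unique, unknown or untested is made for them only; others in the source may bear on it.

Of the compounds shown here, three have been measured in an assay on blood for inhibition of C-X-C chemokine receptor type 3 (Homo sapiens), with a stated time of 30 min; on this read-out higher numbers stand for weaker inhibition and lower numbers for stronger inhibition. Compound 1 `C[C@@H]1CN(c2scnc2-c2nc3ccccc3[nH]2)CCN1C(=O)Cn1cnc2cccnc21` gives 554 nM. Within the data shown here, compound 2 `C[C@@H]1CN(c2sc(C3CC3)nc2-c2nc3ccccc3[nH]2)CCN1C(=O)Cn1cnc2cccnc21` gives 994 nM; the only step made up of a single change, a 1.8-fold higher number from compound 1 to compound 2 (0.25 log units; within the scatter), concerns a substituent on an aromatic carbon of the shared core. Compound 3 `CCOc1ncc(-c2nc(C(F)(F)F)sc2N2CCN(C(=O)Cn3ccc4cccnc43)[C@H](C)C2)cn1` gives 47 nM, the lowest of the three numbers: compound 1 lies beyond the scatter above it, and compound 2 further still.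

Compound 4 `CCOc1ncc(-c2nc(C(F)(F)F)sc2N2CCN(C(=O)Cn3cc(Cl)cn3)[C@H](C)C2)cn1` has not yet been measured. It differs from compound 3 in one place: a group of 6 heavy atoms (3 carbon, 2 nitrogen, 1 chlorine; one five-membered aromatic ring with 2 hetero atoms) in place of a group of 9 heavy atoms (7 carbon, 2 nitrogen; one five-membered aromatic ring with 1 hetero atom, one six-membered aromatic ring with 1 hetero atom), on a saturated chain carbon bound to a carbonyl carbon.

Among the measured compounds shown here, no measured step touches this position. For the measured compounds named here, the one step known, a 1.8-fold higher number from compound 1 to compound 2 (0.25 log units; within the scatter), alters a different part of the molecule and lies within the scatter, so it offers no guide to the size or direction of the change here. Going by the values given here, the change trades a larger group for a smaller one at the same place, and with no precedent among the measured compounds the expectation must be wide. A modest loss of inhibition seems the most likely outcome, expected as a 3.2-fold higher number from compound 3 to compound 4 (0.50 log units; beyond the scatter), though a number close to compound 3 cannot be excluded. Compound 4 is therefore estimated at 150 nM in this assay, within a range of 40 nM to 600 nM.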

Compound 4, half-maximal inhibitory concentration: 245 nM
Beside the measured number, compound 4's estimate is 1.6-fold (0.21 log units) below it, within the range that was stated.
By their numbers in this assay, from the lowest: compound 3; then compound 4; then compounds 1 and 2 (each within the scatter of the next).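

Read in this assay, the first measured step at this position, on a saturated chain carbon bound to a carbonyl carbon, is a 5.2-fold higher number from compound 3 to compound 4 (0.72 log units; beyond the scatter) and shows that the group held here matters to the number. This pair also narrows the comparison: the group that leaves and 4-chloro-1H-pyrazol-1-yl have the same counts of hydrogen-bond donors and acceptors and no net charge, yet they still give different numbers, so those counts alone do not account for the step, while the rings, the heavy atoms and the chlorine do differ. Nothing at hand explains why the number rises at this position.

Compound 4 changes the ring system and adds chlorine in one move, so the compounds shown leave open how much of the step belongs to each. As far as these compounds go, the plain 1H-pyrazol-1-yl group, or 4-methyl-1H-pyrazol-1-yl, at this place on the core of compound 3 would begin to separate the two, and it also remains open whether the same exchange would give a similar step on the core of compound 1.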